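Replacing naphthalen-2-yl in compound 3: expected cytotoxicity

The source may report more compounds than this note shows. Statements on the series, on what has been measured and on what is new or still open speak of the compounds shown alone.

Three compounds have been measured in an ADME assay on BJ cells (Homo sapiens) for cytotoxicity, read by CellTiter-Glo and resazurin assay, with a stated time of 72 h (a higher number here means that more compound is needed for the effect, a lower number that less compound is needed), and every one of them returned a limit of the assay rather than a number:

Compound 1, `CC(C)N(Cc1cccc(OCCCCCC(=O)O)c1)C(=O)c1ccc(-c2ccc3c(c2)OCCO3)cc1`: > 21900 nM
Compound 2, `CC(C)N(Cc1cccc(OCCCCCC(=O)O)c1)C(=O)c1ccc(-c2ccc3cc[nH]c3c2)cc1`: > 26000 nM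
Compound 3, `CCOC(=O)CCCCCOc1cccc(CN(C(=O)c2ccc(-c3ccc4ccccc4c3)cc2)C(C)C)c1`: > 26000 nM

Compound 3 therefore stands at the limit of > 26000 nM in this assay, at which 2 of the 3 values shown sit, a limit it shares with compound 2. Compound 1 stands at the limit of > 21900 nM in this assay, at which 1 of the 3 values shown sits. Among the measured compounds shown here, the single step between measured compounds, a step that the two limits leave unreadable from compound 1 to compound 2, runs from one limit to another, so its size cannot be read, and no step among the measured compounds reaches into the range of real numbers.

Compound 4 is `CCOC(=O)CCCCCOc1cccc(CN(C(=O)c2ccc(-c3cccc(-c4nnc(C)o4)c3)cc2)C(C)C)c1`. It differs from compound 3 in one place: 3-(5-methyl-1,3,4-oxadiazol-2-yl)phenyl in place of naphthalen-2-yl on an aromatic carbon. For the measured compounds named here, no measured step touches this change, and none bears on it in an indirect way either, since all three values are limits.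

Given that compound 3 sits at a limit, compound 4 is expected to behave the same way, and the step of a number no higher from compound 3 to compound 4 (the limit leaves the size open) is expected to be none beyond the scatter. Compound 4 is accordingly estimated at 26000 nM in this assay, with a range from 12000 nM to 60000 nM.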

Compound 4, half-maximal effective concentration: > 26000 nM
Compound 4: no number, only a limit; the forecaster's own chance of this, stated with the estimate: 80%; the middle value sits exactly at the limit.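

Compound 3 and compound 4 both stop at a limit of this assay rather than giving a number, so the size of the step between them cannot be read. The compounds shown leave open what concentration, if any, produces the effect, and whether 3-(5-methyl-1,3,4-oxadiazol-2-yl)phenyl in place of naphthalen-2-yl changes it at all.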